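Pyrimidin-2-yl in Place of Pyridin-2-yl: Expecting Another Limit

The source may report more compounds than this note shows. Statements on the series, on what has been measured and on what is new or still open speak of the compounds shown alone.

Compound 1 `O=C(NCCCN1CCN(c2ccccn2)CC1)c1cc(Cl)cc(Cl)c1`, compound 2 `O=C(NCCCN1CCN(c2cccc(Cl)c2Cl)CC1)c1cc(Cl)cc(Cl)c1` and compound 3 `O=C(NCCCN1CCN(c2ccccn2)CC1)c1cccc2ccccc12` were all tested in an assay on HEK293 cells for inhibition of sodium-dependent dopamine transporter (Homo sapiens), read by scintillation counting; on this read-out lower numbers stand for stronger inhibition and higher numbers for weaker inhibition. Compound 1 gives only a limit of the assay, > 10000 nM. Compound 2 likewise returns only a limit, > 10000 nM. Compound 3 also gives only a limit, > 10000 nM, so compound 3 stands at the same limit as the two others, and no order among the three can be read from these numbers. For the measured compounds named here, the single step between measured compounds, a step that the two limits leave unreadable from compound 1 to compound 2, lies between two limits and so has no readable size. What is known is summed up by the limit of > 10000 nM in this assay, at which 3 of the 3 values shown sit.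

Compound 4 `O=C(NCCCN1CCN(c2ncccn2)CC1)c1cccc2ccccc12` differs from compound 3 by pyrimidin-2-yl in place of pyridin-2-yl on an amine nitrogen in a ring. Going by the values given here, every measured value sits at the limit, and no measured step gives a size or direction to build on, so there is no ground to expect this change to move the number into the readable range. Compound 4 is therefore estimated at 15000 nM, with a range from 5000 nM to 50000 nM, most likely reported again as a limit. This means an expected step that the limit leaves unreadable from compound 3 to compound 4, no change beyond the scatter.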

Compound 4, half-maximal inhibitory concentration: > 10000 nM
Compound 4: only a limit was reported; the forecaster's own chance of this, stated with the estimate: 85%; the middle value does not contradict the limit.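

For the compounds shown here, compound 3 and compound 4 both give only a limit, so the change from pyridin-2-yl to pyrimidin-2-yl yields no step that can be read. Which change, if any, would bring a readable value in this assay stays open: the limit of > 10000 nM in this assay, at which 4 of the 4 values shown sit.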